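The source may hold more compounds than are shown below. What is called first, only, known or untested is meant among the compounds shown, and "the series" means these compounds.

- compound 1 `O=C1NC(O)C(F)=CN1[C@H]1C=C[C@@H](CO)O1`: 32200 nM
- compound 2 `O=c1[nH]c(=O)n([C@@H]2C=C[C@@H](CO)O2)cc1F`: 47400 nM

In a functional assay on PBM cells (Homo sapiens) for cytotoxicity (a lower number here means a stronger inhibitor, a higher number a weaker inhibitor), compound 2 gives 47400 nM, and compound 1 gives 32200 nM. These two values lie within the scatter of each other, so the pair cannot be ranked. The next compound, compound 3 `O=c1[nH]c(=O)n([C@@H]2C=C[C@H](CO)O2)cc1F`, is related to compound 2 by a single change: the two compounds have the same atoms and bonds and differ only in configuration as drawn: 1 of 2 stereo elements differ; a stereocentre at a saturated ring carbon is drawn S in compound 2 and R in compound 3. Within the data shown here, no measured pair in this small set shows what such a change does in this assay. The expectation therefore rests only on the level set by compound 1 at 32200 nM and compound 2 at 47400 nM. No step beyond the scatter is expected, in either direction, although the uncertainty is wide. The expected change is a 1.1-fold higher number from compound 2 to compound 3 (0.02 log units; within the scatter). For compound 3 the estimate is 50000 nM, within an expected range of 18000 nM to 100000 nM.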

Compound 3, half-maximal inhibitory concentration: 2300 nM
The estimate for compound 3 lay 22-fold (1.34 log units) above the measured number; the measured number lies below the stated range.
By their numbers in this assay, from the lowest: compound 3; then compounds 1 and 2 (each within the scatter of the next).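

Changing a single stereocentre at a saturated ring carbon from S to R, with no atom or bond altered, gives a 21-fold lower number from compound 2 to compound 3 (1.31 log units; beyond the scatter) in this assay. Among these compounds, this is the first sign that this assay responds to configuration at this position, since the earlier compounds only set a level and included no pair differing in this way. The large step can be assigned to this stereocentre alone because of the following: the fact that compounds 2 and 3 differ only in the configuration as drawn

What the second stereo element does when it changes alone remains open, as the compounds shown offer no such pair. It is also unknown whether the same preference for R would hold if the hydroxymethyl group were replaced by a carboxylic acid or an amine, or the fluorine by a chlorine or a methyl group.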